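The source may report more compounds than this note shows. Statements on the series, on what has been measured and on what is new or still open speak of the compounds shown alone.

Working notes on the series. Three compounds have numbers in a functional assay on OVCAR-3 cells (Homo sapiens) for inhibition, read by sulforhodamine B assay, with a stated time of 48 h (a lower number here means a stronger inhibitor of growth, a higher number a weaker inhibitor of growth), so far. Compound 1 `COc1ccc(C2CC(=O)C=CO2)cc1` gives 249 uM in this assay. Compound 2 `O=C1C=CCC(/C=C/c2ccc(C(F)(F)F)cc2)O1` gives 167 uM in this assay. Compound 3 `COc1ccc(/C=C/C2CC=CC(=O)O2)cc1` gives 61.5 uM in this assay and stands lowest of the three: the gap to compound 2 is the step of a 2.7-fold lower number from compound 2 to compound 3 (0.43 log units; beyond the scatter), and compound 1 sits higher still, beyond the scatter.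

Compound 4 `COc1ccc(/C=C/C2CC=CC(=O)O2)c(OC)c1` has not yet been measured. Against compound 3 the change is methoxy in place of hydrogen on an aromatic carbon; the new group sits ortho to a group of 9 heavy atoms and meta to the methoxy already present. Within the data shown here, no measured step puts a methoxy in place of hydrogen, so nothing in hand bears directly on this change. Among the measured compounds shown here, the only step involving a methoxy, a 2.7-fold lower number from compound 2 to compound 3 (0.43 log units; beyond the scatter), exchanged it for trifluoromethyl and is a different kind of change. No step beyond the scatter in this assay is expected in either direction. The estimate for compound 4 is 55 uM, with a range of 20 uM to 150 uM. This estimate corresponds to an expected step of a 1.1-fold lower number from compound 3 to compound 4 (0.05 log units; within the scatter).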

Compound 4, concentration for growth inhibition (reported as GI): 5.6 uM
Beside the measured number, compound 4's estimate is 9.8-fold (0.99 log units) above it, and the stated range ends above it.
By their numbers in this assay, from the lowest: compound 4; then compound 3; then compounds 2 and 1 (each within the scatter of the next).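

Placing methoxy in place of hydrogen on this aromatic carbon, ortho to a group of 9 heavy atoms and meta to a methoxy group, gives an 11-fold lower number from compound 3 to compound 4 (1.04 log units; beyond the scatter) in this assay. Among these compounds, this is the first measured step that adds a group to this aromatic ring, and it is larger than a 2.7-fold lower number from compound 2 to compound 3 (0.43 log units; beyond the scatter), a different kind of change that exchanged trifluoromethyl for methoxy. Nothing in hand gives a cause for the size of the new step.

Going by these compounds, whether a hydroxy group or an ethoxy group on this same carbon would give a step of similar size stays open, as does whether the step depends on the methoxy already present. Also open, on these data alone, is whether this added methoxy would give a comparable step on the core of compound 1.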